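Swapping the 2,4,5-trichlorophenyl group of compound 2

The source may report more compounds than this note shows. Statements on the series, on what has been measured and on what is new or still open speak of the compounds shown alone.

In a functional assay on M21 cells (Homo sapiens) for antiproliferative activity, read by sulforhodamine B assay, with a stated time of 48 h (on this read-out lower numbers stand for stronger inhibition and higher numbers for weaker inhibition), compound 1 `CCN1CCN(c2ccc(S(=O)(=O)Oc3cccc(OC)c3)cc2)C1=O` gives 7000 nM and compound 2 `CCCN1CCN(c2ccc(S(=O)(=O)Oc3cc(Cl)c(Cl)cc3Cl)cc2)C1=O` gives 15000 nM as the higher number of the two, a gap beyond the usual scatter. Compound 3 `CCCN1CCN(c2ccc(S(=O)(=O)Oc3cccc(OC)c3)cc2)C1=O` has 3-methoxyphenyl in place of 2,4,5-trichlorophenyl on an oxygen and shares that 3-methoxyphenyl with compound 1. For the measured compounds named here, no measured step isolates this change. A moderate move to a lower number in this assay is expected, since compound 1 with this group stands at 7000 nM in the same test. The expected change is a 3.0-fold lower number from compound 2 to compound 3 (0.48 log units; beyond the scatter) toward stronger inhibition. Compound 3 is estimated at 5000 nM with an expected range of 1700 nM to 14000 nM in this test.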

Compound 3, half-maximal inhibitory concentration: 10000 nM
Estimate against measurement, compound 3: 2.0-fold (0.30 log units) below; the range from low to high includes it.
By their numbers in this assay, from the lowest: compounds 1, 3 and 2 (each within the scatter of the next, the first and the last beyond it).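

In this assay, 3-methoxyphenyl in place of 2,4,5-trichlorophenyl on the oxygen gives a 1.5-fold lower number from compound 2 to compound 3 (0.18 log units; within the scatter), and methyl in place of hydrogen on the chain gives a 1.4-fold higher number from compound 1 to compound 3 (0.15 log units; within the scatter). Each single change thus stays within the scatter, although the two changes together separate compound 1 and compound 2 beyond it. No measured evidence bears on this result. The compounds shown leave open whether an amine or a carboxylic acid on the oxygen-bound phenyl ring, or a longer chain on the ring nitrogen, would move the number beyond the scatter.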